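From chloro to fluoro: one small swap

The source may report more compounds than this note shows. Statements on the series, on what has been measured and on what is new or still open speak of the compounds shown alone.

In a functional assay on MDA-MB-231 cells (Homo sapiens) for antiproliferative activity, read by MTT assay, with a stated time of 24 h (a higher number here means a weaker inhibitor, a lower number a stronger inhibitor), compound 1 `O=C(NNc1ccc(F)cc1)c1ccc(NS(=O)(=O)c2cnc(O)nc2O)cc1` reads > 20000 nM, which is a limit of the assay and not a number. Within the data shown here, compound 2 `O=C(NNC(=O)c1ccccc1Cl)c1ccc(NS(=O)(=O)c2cnc(O)nc2O)cc1` gives 13900 nM, the only actual number so far. Compound 3 `O=C(NNC(=O)c1ccccc1F)c1ccc(NS(=O)(=O)c2cnc(O)nc2O)cc1` differs from compound 2 by fluoro in place of chloro on an aromatic carbon, ortho to a large group. Among the measured compounds shown here, the only measured step is an at least 1.4-fold lower number from compound 1 to compound 2 (0.15 log units; that floor lies within the scatter). Its size is just a floor, set by the limit of > 20000 nM in this assay, at which 1 of the 2 values shown sits, and it concerns a different change, so it gives no direct guide to this swap. The best starting point is therefore the value of compound 2, 13900 nM, with no shift beyond the scatter expected in this assay. The expected change is a 1.1-fold higher number from compound 2 to compound 3 (0.03 log units; within the scatter). For compound 3 the estimate is 15000 nM, with an expected range from 8000 nM to 20000 nM.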

Compound 3, half-maximal inhibitory concentration: > 20000 nM
Compound 3: a limit, no number (the forecaster's own chance of this, stated with the estimate: 30%); at least 1.3-fold (0.12 log units) between middle value and limit.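

Compound 3 reads as a limit of this assay and not as a number. Fluoro in place of chloro on this aromatic carbon, ortho to a large group, therefore gives only a floor, an at least 1.4-fold higher number from compound 2 to compound 3 (0.15 log units; that floor lies within the scatter), so the real size of the change could be small or much larger, and chloro remains the only group here with a readable number. The step between the two limits cannot be read, and the assay's ceiling now caps most of this small set: the limit of > 20000 nM in this assay, at which 2 of the 3 values shown sit.

On these data alone, whether the swap truly weakens activity, or only tips a value already close to the ceiling past it, stays open. Also open, as far as these compounds go, is how a methyl or a methoxy group on this same aromatic carbon would read in this assay.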